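Piperidinyl in Place of Chloro: An Expected Step

A few compounds are considered here, and "the series" means these few. Any claim that something is new, unique, unknown or untested is made for them only; others in the source may bear on it.

Compound 1 `Nc1cc(Nc2cc(Cl)cc(Cl)c2)nc(N)n1` gives > 180000 nM in an assay on cells for inhibition of S-adenosylmethionine decarboxylase proenzyme (Homo sapiens), read by mass spectrometry, at pH 7.2; a higher number here means a weaker inhibitor, a lower number a stronger inhibitor; that value is a limit of the assay.
Compound 2 `Cc1cc(Nc2cc(Cl)c(Cl)c(Cl)c2)nc(N)n1` gives > 63000 nM in this assay; that value is also a limit.

Compound 2 stands only at a limit (the limit of > 63000 nM in this assay, at which 1 of the 2 values shown sits), so its place among the numbers shown cannot be fixed more closely. The other value shown is likewise a limit (the limit of > 180000 nM in this assay, at which 1 of the 2 values shown sits). Compound 3 `Cc1cc(Nc2cc(Cl)c(N3CCCCC3)c(Cl)c2)nc(N)n1` differs from compound 2 by piperidin-1-yl in place of chloro on an aromatic carbon. No step between measured compounds is shown, so nothing measured tells the size of this change in this assay. The step that the limit leaves unreadable from compound 2 to compound 3 is expected to be none beyond the scatter. Compound 3 is estimated at 80000 nM, between 20000 nM and 300000 nM.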

Compound 3, half-maximal inhibitory concentration: > 180000 nM
Compound 3: only a limit was reported; the forecaster's own chance of this, stated with the estimate: 70%; middle value at least 2.2-fold (0.35 log units) from the limit.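

In this assay compound 3 gives > 180000 nM, which is a limit. Compound 2 also stands only at a limit, so no step can be read between compound 2 and compound 3. The compounds shown leave open whether piperidin-1-yl in place of chloro changes inhibition at all.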